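A Longer Link on a Long-Lived Compound

This account rests on a few compounds, and the source may have more. Where it says the series, first, only, none or still open, it means among the compounds named here.

In an ADME assay on microsomes from liver (Homo sapiens) for metabolic stability (a higher number here means that the compound lasts longer, a lower number that the compound disappears faster), compound 1 `CC(C)[C@@H](c1ccc(-c2ccc3cccc(F)c3c2)[nH]c1=O)[C@@H]1OC(=O)NC1=O` gives > 3 h, which is a limit and not a number. Compound 3 `C/C(=C1/OC(=O)NC1=O)C(c1ccc(-c2ccc3cccc(F)c3c2)[nH]c1=O)C(C)C` gives > 3 h, which is also a limit. Compound 2 `CCC(/C=C1\OC(=O)NC1=O)(CC)c1ccc(-c2ccc3cccc(C(F)(F)F)c3c2)[nH]c1=O` gives a true number, 0.353 h. Compound 1 therefore sits with compound 3 at the limit of > 3 h in this assay, at which 2 of the 3 values shown sit.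

Compound 4 `CC(C)[C@H](C[C@H]1OC(=O)NC1=O)c1ccc(-c2ccc3cccc(F)c3c2)[nH]c1=O` departs from compound 1 in one place: (2,4-dioxo-1,3-oxazolidin-5-yl)methyl in place of 2,4-dioxo-1,3-oxazolidin-5-yl on a saturated chain carbon bound to an aromatic carbon and a saturated chain carbon. Going by the values given here, no measured pair isolates this change, so the expectation in this assay is a small downward shift at most, not clearly beyond the usual scatter. The estimated step is an at least 1.2-fold lower number from compound 1 to compound 4 (0.07 log units; that floor lies within the scatter). For compound 4, the expected half-life is 2.5 h, with an estimated range of 0.9 h to 6 h.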

Compound 4, half-life: 1.68 h
Compound 4: middle estimate off by 1.5-fold (0.17 log units), on the high side; the range from low to high includes it.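

In this assay, placing (2,4-dioxo-1,3-oxazolidin-5-yl)methyl where 2,4-dioxo-1,3-oxazolidin-5-yl stood on this saturated chain carbon gives an at least 1.7-fold lower number from compound 1 to compound 4 (0.25 log units; that floor lies within the scatter). Going by these compounds alone, this is the first one-place comparison at this position, and compound 4 gives a true number rather than a limit. The full size of the step stays hidden, since compound 1 has only a limit: the limit of > 3 h in this assay, at which 2 of the 4 values shown sit.

The compounds shown leave open whether the step really goes beyond the scatter. They also leave open what a longer chain, or a carboxylic acid in place of the ring, would do here.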